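The source may report more compounds than this note shows. Statements on the series, on what has been measured and on what is new or still open speak of the compounds shown alone.

In a functional assay on NCI-H1975 cells (Homo sapiens) for antiproliferative activity, read by MTT assay, with a stated time of 72 h (on this read-out lower numbers stand for stronger inhibition and higher numbers for weaker inhibition), compound 3 `NS(=O)(=O)c1ccc(NC(=S)Nc2ccc3ncnc(Nc4ccc(F)c(Br)c4)c3c2)cc1` gives 9980 nM. Compound 1 `NS(=O)(=O)c1ccc(NC(=S)Nc2ccc3ncnc(Nc4ccc(F)c(Cl)c4)c3c2)cc1` gives 15800 nM and compound 2 `C#Cc1cccc(Nc2ncnc3ccc(NC(=S)Nc4ccc(S(N)(=O)=O)cc4)cc23)c1` gives 13400 nM in this assay, so compound 3 sits with both inside the usual scatter: a 1.6-fold lower number from compound 1 to compound 3 (0.20 log units; within the scatter), a 1.2-fold lower number from compound 1 to compound 2 (0.07 log units; within the scatter), a 1.3-fold lower number from compound 2 to compound 3 (0.13 log units; within the scatter). Compound 4 `NS(=O)(=O)c1ccc(NC(=S)Nc2ccc3ncnc(Nc4cccc(Br)c4)c3c2)cc1` is the next step: hydrogen in place of fluoro on an aromatic carbon. Going by the values given here, no measured pair removes a fluoro; the nearest comparisons are the swaps on the same aryl group just given, and each stayed within the scatter. The expected step is therefore a 1.1-fold higher number from compound 3 to compound 4 (0.04 log units; within the scatter), nothing beyond the scatter. Compound 4 is estimated at 11000 nM, with a range from 4500 nM to 27000 nM.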

Compound 4, half-maximal inhibitory concentration: 11000 nM
For compound 4 middle estimate and measured number coincide at the digits printed, and the stated range covers the measured number.
By their numbers in this assay, from the lowest: compounds 3, 4, 2 and 1 (each within the scatter of the next).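

In this assay, going by these compounds alone, a fluoro is changed on its own for the first time, and hydrogen in its place gives a 1.1-fold higher number from compound 3 to compound 4 (0.04 log units; within the scatter), so at this spot, ortho to a bromo group, the fluoro can go without the number leaving the scatter. Within the data shown here, the other comparisons read a 1.2-fold lower number from compound 2 to compound 4 (0.09 log units; within the scatter) and a 1.4-fold lower number from compound 1 to compound 4 (0.16 log units; within the scatter), which places compound 4 among the earlier compounds rather than apart from them. No evidence on the cause is available here.

From the compounds shown here alone, whether a larger group at this spot, such as methoxy or an amine, would move the number beyond the scatter remains open.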